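One Change on the Carbonyl Carbon of Compound 2

The compounds below may be only part of what the source reports. "The series", "measured", "known", "first", "only" and "open" are said of these compounds alone.

Compound 1 `O=C(Nc1cccc(-n2cc(-c3ccncc3)c(-c3cc(O)cc(Cl)c3)n2)c1)Nc1ccc(Cl)c(Cl)c1` gives -23% in a functional assay on HCT-15 cells (Homo sapiens) for inhibition, read by sulforhodamine B assay, with a stated time of 48 h, tested at 100 uM; on this read-out higher numbers stand for a weaker effect at the one concentration tested and lower numbers for a stronger effect.
Compound 2 `COc1cc(Cl)cc(-c2nn(-c3cccc(NC(=O)Nc4ccc(Cl)c(Cl)c4)c3)cc2-c2ccncc2)c1` gives -9% in this assay.

For the measured compounds named here, these are the only two numbers so far. Going by the values given here, compound 2 stands highest of the two; its nearest neighbour is compound 1, and the single step between them, a number 14 percentage points higher from compound 1 to compound 2 (beyond the scatter), was a methyl in place of hydrogen on an oxygen on an aromatic ring, a spot untouched in what follows.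

Compound 3 `COc1cc(Cl)cc(-c2nn(-c3cccc(NC(=O)c4cccc(C(F)(F)F)c4)c3)cc2-c2ccncc2)c1` has not yet been measured. It differs from compound 2 in one place: 3-(trifluoromethyl)phenyl in place of (3,4-dichlorophenyl)amino on a carbonyl carbon. The group that leaves sits on a carbonyl carbon whose other neighbour is an amide-type nitrogen, so the change concerns the outer arm of the shared core rather than the aromatic oxygen varied before. Among the compounds with values here, no measured step bears on this place, and the one step available, a number 14 percentage points higher from compound 1 to compound 2 (beyond the scatter), offers no guidance on direction or size. The expected step of a number 9 percentage points higher from compound 2 to compound 3 (within the scatter) is therefore placed near no change beyond the scatter, with a wide range. Compound 3 is estimated to give 0%, somewhere between -25% and 35%.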

Compound 3, a percentage reported as activity, at one concentration (the size of the read-out at that concentration, not a potency): 28%
Compound 3: the middle estimate sits 28 percentage points below what was measured; low and high end bracket the measured number.
By their numbers in this assay, from the lowest: compound 1; then compound 2; then compound 3.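

The outer arm on the carbonyl carbon turns out to matter in this assay: replacing (3,4-dichlorophenyl)amino with 3-(trifluoromethyl)phenyl gives a number 37 percentage points higher from compound 2 to compound 3 (beyond the scatter), a large step towards a weaker effect at the one concentration tested. For the compounds shown here, this is the first measured change at this place, and it shows that the stronger effect of compound 2 does not survive this swap, even though both arms carry one six-membered aromatic ring of carbon only and are close in size, at 9 and 10 heavy atoms. The swap alters several things at once, as the nitrogen with its hydrogen-bond donor leaves while two chlorines give way to a trifluoromethyl group, and nothing available here shows why the read-out moved.

The compounds shown therefore leave open whether the linking nitrogen or the ring's substituents account for the step, a question that 3-(trifluoromethyl)phenylamino or 3,4-dichlorophenyl on the same carbonyl carbon would help to separate. They also leave open how a simple amine or a short alkyl chain would behave at this place, and whether the step would look the same with the aromatic hydroxyl of compound 1 in place of the methoxy group.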